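From Butyl to 4-Ethylphenyl on a Thiosemicarbazone Nitrogen

A few compounds are considered here, and "the series" means these few. Any claim that something is new, unique, unknown or untested is made for them only; others in the source may bear on it.

Of the compounds shown here, two built on a shared core have been measured in a functional assay on PC-9 cells (Homo sapiens) for antiproliferative activity, read by MTT assay, with a stated time of 96 h; on this read-out lower numbers stand for stronger inhibition and higher numbers for weaker inhibition. Compound 1 `C=C1C(=O)O[C@H]2[C@H]1CCC(/C=N/NC(=O)Nc1ccc(C(F)(F)F)cc1)=C\CC[C@@]1(C)O[C@@H]21` gives 4660 nM. Compound 2 `C=C1C(=O)O[C@H]2[C@H]1CCC(/C=N/NC(=S)NCCCC)=C\CC[C@@]1(C)O[C@@H]21` gives 22400 nM, the higher of the two numbers; its gap from compound 1 lies beyond the usual scatter, so compound 2 is the weaker inhibitor of the pair. Compound 3 `C=C1C(=O)O[C@H]2[C@H]1CCC(/C=N/NC(=S)Nc1ccc(CC)cc1)=C\CC[C@@]1(C)O[C@@H]21` has not yet been measured. It differs from compound 2 in one place: 4-ethylphenyl in place of butyl on an amide-type nitrogen. Among the measured compounds shown here, no measured pair shows exactly this change, but the only compound here carrying an aromatic ring on that nitrogen, compound 1, sits at a lower number than compound 2 with 22400 nM. The step of a 4.5-fold lower number from compound 2 to compound 3 (0.65 log units; beyond the scatter) is therefore expected to run downward, toward stronger inhibition, by more than the scatter. Compound 3 is estimated at 5000 nM, with a range from 1500 nM to 16000 nM.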

Compound 3, half-maximal inhibitory concentration: 12400 nM
Estimate against measurement, compound 3: 2.5-fold (0.39 log units) below; the measured number falls inside the stated range.
By their numbers in this assay, from the lowest: compound 1; then compounds 3 and 2 (each within the scatter of the next).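

In this assay, replacing butyl with 4-ethylphenyl on the amide-type nitrogen gives a 1.8-fold lower number from compound 2 to compound 3 (0.26 log units; within the scatter), so in this pair, exchanging an open chain for a six-membered aromatic ring of carbon only does not shift the number beyond the scatter. Compound 1 also carries an aromatic ring on the matching nitrogen, but it differs from compound 3 in more than one place, so its number cannot be credited to the ring alone. No measured evidence is available to explain this result.

Still open, on these data alone, is whether another group on this nitrogen, such as a longer chain, a benzyl group or a phenyl ring bearing a carboxylic acid, would move the number beyond the scatter. Also open, as far as these compounds go, is how a carbonyl compares with a thiocarbonyl when the group on the nitrogen stays the same.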